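Para-methyl removal in aryltriazenes and azobenzenes: Vero cytotoxicity

A few compounds are considered here, and "the series" means these few. Any claim that something is new, unique, unknown or untested is made for them only; others in the source may bear on it.

Measured compounds in an ADME assay on Vero cells (Chlorocebus sabaeus) for cytotoxicity, read by crystal violet staining; a higher number here means that more compound is tolerated, a lower number that less compound is tolerated:
- compound 1 `Cc1ccc(/N=N/N(C)c2ccccc2)cc1`: 58000 nM
- compound 2 `Cc1ccc(/N=N/c2ccc(NCCCN(C)C)cc2)cc1`: 50000 nM
- compound 3 `CN(/N=N/c1ccccc1)c1ccccc1`: 50000 nM

Compound 1 and compound 3 share a core and differ by one change, (hydrogen in place of methyl on an aromatic carbon), which gives a 1.2-fold lower number from compound 1 to compound 3 (0.06 log units; within the scatter). Compound 2 stands level with compound 3 at the digits given, and its value lies within the scatter of the value of compound 1. How the core of compound 2 differs from the core of compound 1 is not broken down here.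

Compound 4 `CN(C)CCCNc1ccc(/N=N/c2ccccc2)cc1` is not yet measured in this assay. It differs from compound 2 by hydrogen in place of methyl on an aromatic carbon, the same change as that from compound 1 to compound 3, at the same kind of place. Since that earlier step, a 1.2-fold lower number from compound 1 to compound 3 (0.06 log units; within the scatter), stayed within the scatter, the step from compound 2 to compound 4 is expected to be of like size, a 1.1-fold lower number from compound 2 to compound 4 (0.04 log units; within the scatter). On that basis compound 4 is expected to give about 46000 nM in this assay, with a range from 25000 nM to 80000 nM.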

Compound 4, half-maximal cytotoxic concentration: 30000 nM
Beside the measured number, compound 4's estimate is 1.5-fold (0.19 log units) above it, and the stated range covers the measured number.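

In this assay, the change from 4-methylphenyl to phenyl on the core of compound 2 gives a 1.7-fold lower number from compound 2 to compound 4 (0.22 log units; within the scatter). Set beside the earlier step on the core of compound 1, the change carries from one core to the other with no difference that can be told apart: the same change on two cores in this assay, a 1.2-fold lower number (0.06 log units; within the scatter) from compound 1 to compound 3 and a 1.7-fold lower number (0.22 log units; within the scatter) from compound 2 to compound 4, 1.4-fold (0.16 log units) apart, within the scatter of two such steps This shows that, on these two cores, the change leaves the number within the scatter; it does not show that the methyl group has any real effect on tolerated concentration, and two pairs do not establish a rule for other cores in the series.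

Still open, going by these compounds, is whether another group on the same aromatic carbon, such as chlorine, a methoxy group or a carboxylic acid, would give a step beyond the scatter. Also open, on these data alone, is whether the step stays alike when the amine chain of compound 2 is replaced by a shorter or longer chain.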